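The compounds below may be only part of what the source reports. "The series", "measured", "known", "first", "only" and "open" are said of these compounds alone.

Working notes on a series of three measured compounds built on the shared core of compound 1 `O=c1[nH]c2ccccc2oc1=O`. In a functional assay with Rattus norvegicus as the target (on this read-out lower numbers stand for stronger inhibition and higher numbers for weaker inhibition), compound 1 gives 42000 nM. Compound 2 `O=c1[nH]c2ccc(O)cc2oc1=O` gives 170000 nM, and compound 3 `Cc1ccc2[nH]c(=O)c(=O)oc2c1` gives 32000 nM. Compound 3 and compound 1 lie within the scatter of each other, a 1.3-fold lower number from compound 1 to compound 3 (0.12 log units; within the scatter), so no order between them is claimed; only compound 2 stands clearly apart, a 5.3-fold lower number from compound 2 to compound 3 (0.73 log units; beyond the scatter). Compound 4 `O=C(O)c1ccc2[nH]c(=O)c(=O)oc2c1` is not yet measured and differs from compound 3 in one place: carboxy in place of methyl on an aromatic carbon. Within the data shown here, no measured step involves carboxy anywhere on the core. The nearest guides are the two steps that concern hydroxy, a 4.0-fold higher number from compound 1 to compound 2 (0.61 log units; beyond the scatter) and a 5.3-fold lower number from compound 2 to compound 3 (0.73 log units; beyond the scatter), in both of which the number is higher with hydroxy present than with hydrogen or methyl. Carboxy likewise enters with one hydrogen-bond donor and one hydrogen-bond acceptor where methyl leaves, so a modest rise in number is expected for compound 4, roughly a 3.1-fold higher number from compound 3 to compound 4 (0.49 log units; beyond the scatter). Compound 4 is therefore estimated at 100000 nM, with a range from 35000 nM to 300000 nM.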

Compound 4, half-maximal inhibitory concentration: 16000 nM
Beside the measured number, compound 4's estimate is 6.3-fold (0.80 log units) above it; measured number below the stated range.
By their numbers in this assay, from the lowest: compounds 4, 3 and 1 (each within the scatter of the next, the first and the last beyond it); then compound 2.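

In this assay carboxy in place of methyl gives a 2.0-fold lower number from compound 3 to compound 4 (0.30 log units; within the scatter) and so leaves the two groups unseparated at this place, which shows that a hydrogen-bond donor and acceptor entering here do not by themselves raise the number as seen with hydroxy. Carboxy and hydroxy, the two oxygen-bearing groups in the series, stand far apart with an 11-fold lower number from compound 2 to compound 4 (1.03 log units; beyond the scatter) as the largest step in the series. Carboxy also separates from hydrogen with a 2.6-fold lower number from compound 1 to compound 4 (0.42 log units; beyond the scatter) in the lower direction, which methyl did not do.

Nothing accompanies these numbers that could explain the carboxy result. From the compounds shown here alone, whether the free carboxy group is needed stays open, since a methyl ester, a primary amide or an amine at this place would each bear on that question, and carboxy elsewhere on the shared core is equally unknown.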